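The source may hold more compounds than are shown below. What is called first, only, known or untested is meant among the compounds shown, and "the series" means these compounds.

Of the compounds shown here, two from this series have been measured in an ADME assay on PC-3 cells (Homo sapiens) for cytotoxicity, read by WST assay, tested at 100 uM (on this read-out higher numbers stand for more inhibition at the one concentration tested (going by the name of the read-out) and lower numbers for less inhibition), so far. Within the data shown here, compound 1 `O=C(Nc1ccc(Cl)cc1)C1CCCN(C(=O)c2cccc(-c3nccs3)c2)C1` gives 32% in this assay, the lower of the two numbers known. Compound 2 `O=C(Nc1cccc(CN2CCCC2)c1)C1CCCN(C(=O)c2cc(C(F)(F)F)cc(C(F)(F)F)c2)C1` gives 51% in this assay, a higher number that lies beyond the usual scatter; the two compounds differ in several places, so no single structural change can be tied to that gap.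

Compound 3 `O=C(Nc1ccc(Cl)cc1)C1CCCN(C(=O)c2cccc(-c3ccco3)c2)C1` differs from compound 1 in just one place: furan-2-yl in place of 1,3-thiazol-2-yl on an aromatic carbon. Both groups are small five-membered aromatic rings attached at the same spot on the shared core. Among the measured compounds shown here, with only two measured compounds and no single-change step among them, there is little to go on. The step from compound 1 to compound 3 is expected to be small, no change at the digits printed from compound 1 to compound 3 (within the scatter), not clearly beyond the scatter in either direction. Compound 3 is therefore estimated at 32%, with a range from 15% to 50%.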

Compound 3, a percentage reported as inhibition, at one concentration (the size of the read-out at that concentration, not a potency): 0%
Estimate against measurement, compound 3: 32 percentage points above, outside the stated range (below it).
By their numbers in this assay, from the lowest: compound 3; then compound 1; then compound 2.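

In this assay, this place on the shared core proved sensitive: furan-2-yl in place of 1,3-thiazol-2-yl gives a number 32 percentage points lower from compound 1 to compound 3 (beyond the scatter), although both groups are five-membered aromatic rings of 5 heavy atoms with no net charge. Two groups that look alike on paper therefore need not read alike here, and this step goes with a change of hetero atoms alone, nitrogen and sulfur giving way to a single oxygen. No measurement at hand explains why the step is so large.

Still open, on these data alone, is what other groups would give at this place, such as a plain phenyl ring, a pyridine ring or an amine. As far as these compounds go, it is also open whether the same swap would give a step of similar size on a compound with different groups elsewhere on the core.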